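Substituent swap on the shared core: compound 2 to compound 3

This account rests on a few compounds, and the source may have more. Where it says the series, first, only, none or still open, it means among the compounds named here.

Measured so far:
compound 1 `CC(C)c1ccccc1-c1nccc(NCc2ccc(-c3cccnc3)cc2)n1` gives 150 nM
compound 2 `CC(C)c1ccccc1-c1ncc(N(C)C)c(NCc2ccc(-c3cccnc3)cc2)n1` gives 190 nM

Both numbers come from an assay on a protein complex for inhibition of ubiquitin carboxyl-terminal hydrolase 1/WD repeat-containing protein 48 (Homo sapiens), read by fluorescence; a higher number here means a weaker inhibitor, a lower number a stronger inhibitor. For the measured compounds named here, compound 2 stands highest of the two, but its only neighbour is compound 1, and the step of a 1.3-fold higher number from compound 1 to compound 2 (0.10 log units; within the scatter) is within the scatter, so the two compounds cannot be ordered on these data.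

Compound 3 `CSc1cnc(-c2ccccc2C(C)C)nc1NCc1ccc(-c2cccnc2)cc1` is the next member. Its difference from compound 2 is methylsulfanyl in place of dimethylamino on an aromatic carbon, the change sitting on an aromatic carbon of a six-membered aromatic ring with 2 nitrogen, ortho to a large group and para to the 2-isopropylphenyl group.

Going by the values given here, only one measured step touches this ring carbon: a 1.3-fold higher number from compound 1 to compound 2 (0.10 log units; within the scatter), which put dimethylamino where hydrogen had been and stayed within the scatter. Among the compounds with values here, no measured pair exchanges dimethylamino for methylsulfanyl, so nothing shows that this carbon moves the read-out.

For compound 3 the expected step is therefore a 1.1-fold higher number from compound 2 to compound 3 (0.02 log units; within the scatter), none beyond the scatter. Compound 3 is estimated at 200 nM, with a range from 80 nM to 500 nM.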

Compound 3, half-maximal inhibitory concentration: 110 nM
Compound 3: middle estimate off by 1.8-fold (0.26 log units), on the high side; the range from low to high includes it.
By their numbers in this assay, from the lowest: compounds 3, 1 and 2 (each within the scatter of the next).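

In this assay, methylsulfanyl on this aromatic carbon gives a 1.7-fold lower number from compound 2 to compound 3 (0.24 log units; within the scatter) and, against the unsubstituted carbon, a 1.4-fold lower number from compound 1 to compound 3 (0.13 log units; within the scatter). Hydrogen, dimethylamino and methylsulfanyl therefore cannot be ordered at this position, which now accepts a sulfur-bearing substituent as well as a nitrogen-bearing one without a step beyond the scatter. No measurement bears on why these three compounds read alike.

Still open, going by these compounds, is whether any group on this carbon moves the read-out beyond the scatter, for instance a carboxylic acid, a primary amine or a longer alkyl chain. Also open, on these data alone, is whether the same indifference to the substituent on this carbon would hold if the 2-isopropylphenyl group or another part of the shared core were changed.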